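A few compounds are considered here, and "the series" means these few. Any claim that something is new, unique, unknown or untested is made for them only; others in the source may bear on it.

Of the compounds shown here, three share one core and have been tested in a functional assay on BXPC-3 cells (Homo sapiens) for cytotoxicity, read by MTT assay, with a stated time of 72 h; on this read-out lower numbers stand for stronger inhibition and higher numbers for weaker inhibition. The bare core, compound 2 `O=C1C=CC(=O)c2ncncc21`, gives 19400 nM. Adding an aniline-type substituent brings the number down: compound 3 `CC(=O)c1cccc(NC2=CC(=O)c3ncncc3C2=O)c1` gives 5200 nM, and compound 1 `CCc1ccc(-c2ccc(NC3=CC(=O)c4ncncc4C3=O)cc2)cc1` gives 3100 nM. Compound 1 thus has the lowest of the three numbers, though its gap to compound 3 lies within the usual scatter, while its gap to compound 2 lies beyond it.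

Compound 4 `O=C1C(Nc2ccc(Oc3ccccc3)cc2)=CC(=O)c2ncncc21` has not yet been measured. It differs from compound 1 in one place: phenoxy in place of 4-ethylphenyl on an aromatic carbon. Within the data shown here, no measured pair shows exactly this kind of swap, so the expectation rests on compound 1 and compound 3 alone, whose values sit close together despite different groups on the aniline ring. The step from compound 1 to compound 4 is therefore expected to be small, a 1.3-fold higher number from compound 1 to compound 4 (0.11 log units; within the scatter), with a slightly higher number but not beyond the scatter. For compound 4 the estimate in this assay is 4000 nM, with a likely range from 1500 nM to 11000 nM.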

Compound 4, half-maximal inhibitory concentration: 3600 nM
Compound 4: middle estimate off by 1.1-fold (0.05 log units), on the high side; the measured number falls inside the stated range.
By their numbers in this assay, from the lowest: compounds 1, 4 and 3 (each within the scatter of the next); then compound 2.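

In this assay, among these compounds, putting phenoxy in place of 4-ethylphenyl gives a 1.2-fold higher number from compound 1 to compound 4 (0.06 log units; within the scatter), the first direct one-place comparison in this set. At this position, therefore, the two groups cannot be told apart, even though phenoxy carries an oxygen and a hydrogen-bond acceptor that 4-ethylphenyl lacks. Nothing available here explains this result.

Both groups place a second aromatic ring at this position, so the compounds shown leave open what a group without such a ring, such as an amine, a carboxylic acid or a longer alkyl chain, would do there. The swap also changes two things at once, the oxygen link and the ethyl end, and a plain phenyl group would be needed to separate them.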